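This account rests on a few compounds, and the source may have more. Where it says the series, first, only, none or still open, it means among the compounds named here.

The series rests on one shared core, seen in compound 1 `Cc1nnsc1CO/N=C/c1c(C)nn(C)c1Oc1ccc(F)cc1` and compound 2 `CCCc1nnsc1CO/N=C/c1c(C)nn(C)c1Oc1ccc(F)cc1`. In a functional assay on PANC-1 cells (Homo sapiens) for inhibition, read by MTT assay, with a stated time of 48 h (on this read-out higher numbers stand for weaker inhibition and lower numbers for stronger inhibition), compound 1 reaches only the limit of the assay, > 50000 nM. In this assay compound 2 likewise returns only a limit, > 50000 nM. Among the compounds with values here, the single measured step, a step that the two limits leave unreadable from compound 1 to compound 2, therefore cannot be read, since both of its ends sit at the limit of > 50000 nM in this assay, at which 2 of the 2 values shown sit. Compound 2 thus stands at the limit of the assay, without a number of its own.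

The unmeasured compound 3 `CCCc1nnsc1CO/N=C/c1c(C)nn(C)c1Cl` differs from compound 2 by chloro in place of 4-fluorophenoxy on an aromatic carbon. Within the data shown here, no measured step bears on this exchange: the only step recorded is unreadable, so nothing in the data shows how large a change in this assay such a replacement produces, or in which direction. With both measured anchors at the limit, the expectation for compound 3 is that it too will fail to give a readable number. Compound 3 is accordingly estimated at 60000 nM, between 20000 nM and 200000 nM. The step this implies, a step that the limit leaves unreadable from compound 2 to compound 3, is expected to be nothing that the scatter would let one tell apart.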

Compound 3, half-maximal inhibitory concentration: > 50000 nM
Compound 3 was reported as a limit (the forecaster's own chance of this, stated with the estimate: 75%); the middle value is on the limit's open side.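

Within the data shown here, compound 3, like compound 2, returns only a limit in this assay, so the exchange of 4-fluorophenoxy for chloro between these two compounds gives no step that can be read: the limit of > 50000 nM in this assay, at which 3 of the 3 values shown sit.

The compounds shown leave open what change to the shared core, if any, would bring a readable number in this assay, and how large either exchange's step would be or in which direction it would run.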